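This account rests on a few compounds, and the source may have more. Where it says the series, first, only, none or still open, it means among the compounds named here.

Measured compounds:
compound 1 `O=S(=O)(NCCCCNCc1ccc(Br)cc1)c1cc(C(F)(F)F)cc(C(F)(F)F)c1` — 2100 nM
compound 2 `O=S(=O)(NCCCNCc1ccc(Cl)c(Cl)c1)c1cc(C(F)(F)F)cc(C(F)(F)F)c1` — 1500 nM

In a functional assay on A2780 cells (Homo sapiens) for inhibition, read by MTT assay, with a stated time of 72 h (a higher number here means a weaker inhibitor of growth, a lower number a stronger inhibitor of growth), compound 2 gives the lowest number of the two, with compound 1 the nearest at a 1.4-fold lower number from compound 1 to compound 2 (0.15 log units; within the scatter). Compound 3 `CN(CCCNS(=O)(=O)c1cc(C(F)(F)F)cc(C(F)(F)F)c1)Cc1ccccc1` differs from compound 2 by benzyl(methyl)amino in place of (3,4-dichlorobenzyl)amino on a saturated chain carbon, three bonds along the chain from a sulfonamide nitrogen. Among the compounds with values here, the only measured step, from compound 1 to compound 2, also changed the benzyl-bearing end of the chain and stayed within the scatter, so it gives little guidance on size or direction. Compound 3 is expected to show a modest step upward, a 2.7-fold higher number from compound 2 to compound 3 (0.43 log units; beyond the scatter). The estimate for compound 3 is 4000 nM, with a range from 1500 nM to 12000 nM.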

Compound 3, concentration for 50% growth inhibition: 28000 nM
Estimate against measurement, compound 3: 7.0-fold (0.85 log units) below; the measured number lies above the stated range.
By their numbers in this assay, from the lowest: compounds 2 and 1 (each within the scatter of the next); then compound 3.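

In this assay, this end of the chain proves sensitive to change: a 19-fold higher number from compound 2 to compound 3 (1.27 log units; beyond the scatter) and a 13-fold higher number from compound 1 to compound 3 (1.12 log units; beyond the scatter) are both large, while a 1.4-fold lower number from compound 1 to compound 2 (0.15 log units; within the scatter) showed no clear difference. The benzyl(methyl)amino group differs in two ways at once, with no halogen on its ring and no hydrogen-bond donor, so these steps cannot separate the two changes. Nothing available explains the weaker growth inhibition.

Still open, going by these compounds, is how the plain benzylamino group, with its amine hydrogen kept, would behave. The same holds for (3,4-dichlorobenzyl)(methyl)amino, which keeps the chlorines but adds the methyl.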